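The compounds below may be only part of what the source reports. "The series", "measured", "known", "first", "only" and "open" are said of these compounds alone.

Series notes on the shared core of compound 1 `COc1ccc(S(C)(=O)=O)c(NCC2=NCCN2)c1`. In a functional assay for agonist activity at Alpha-1B adrenergic receptor (Homo sapiens) (on this read-out higher numbers stand for an effect only at larger amounts of compound and lower numbers for an effect already at smaller amounts), compound 1 gives < 100000 nM, which is a limit of the assay and not a number. Compound 2 `CS(=O)(=O)c1cccc(F)c1NCC1=NCCN1` likewise gives only a limit, < 100000 nM, in this assay. Compound 3 `COc1ccc(SC)c(NCC2=NCCN2)c1` gives 3.63 nM in this assay. Going by the values given here, the only single-point step from a measured neighbour, a step that the limit leaves unreadable from compound 1 to compound 3, cannot be sized since (the limit of < 100000 nM in this assay, at which 2 of the 3 values shown sit). Compound 4 `CS(=O)(=O)c1ccc(C(F)(F)F)cc1NCC1=NCCN1` carries trifluoromethyl in place of methoxy on an aromatic carbon and keeps the methylsulfonyl group of compound 1. Among the compounds with values here, no measured step bears directly on this change, so the expected step that the limit leaves unreadable from compound 1 to compound 4 rests on compound 1 alone, whose value < 100000 nM is a limit. Compound 4 is therefore estimated at 10000 nM, within 300 nM to 100000 nM, with a fair chance that this assay again returns only a limit.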

Compound 4, half-maximal effective concentration: < 100000 nM
Compound 4 was reported as a limit; the forecaster's own chance of this, stated with the estimate: 50%; the middle value does not contradict the limit.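

No step from compound 1 to compound 4 can be read, because both values are limits and not numbers: the limit of < 100000 nM in this assay, at which 3 of the 4 values shown sit.

From the compounds shown here alone, whether trifluoromethyl in place of methoxy changes the result at all in this assay stays open.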